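The compounds below may be only part of what the source reports. "The series", "measured", "known", "first", "only" and "open" are said of these compounds alone.

Working notes on the series. Compound 3 `COC(=O)c1ccnc(O[C@@H]2CC[C@@H](C)N(C(=O)c3ccccc3-n3nccn3)C2)c1` stands lowest of the two numbers given in a functional assay on CHO-K1 cells for antagonist activity at Orexin/Hypocretin receptor type 1 (Homo sapiens), read by FLIPR and calcium flux (a higher number here means a weaker inhibitor, a lower number a stronger inhibitor), with 1800 nM. Compound 1 `CC(C)OC(=O)c1ccccc1C(=O)N1C[C@H](Oc2cc(C#N)ccn2)CC[C@H]1C` gives 3300 nM in this assay, which is within the scatter of compound 3. Compound 2 `C[C@@H]1CC[C@@H](Oc2cc(C#N)ccn2)CN1C(=O)c1ccccc1CC(F)(F)F` gives only a limit of the assay, > 10000 nM. Going by the values given here, the one measured step, an at least 3.0-fold higher number from compound 1 to compound 2 (0.48 log units; beyond the scatter), is described by the limit of > 10000 nM in this assay, at which 1 of the 3 values shown sits, and changes the group on the aromatic carbon of the amide ring, not the ether side.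

Compound 4 `Cc1cccc(O[C@@H]2CC[C@@H](C)N(C(=O)c3ccccc3-n3nccn3)C2)n1` is not yet measured. It differs from compound 3 by 6-methylpyridin-2-yl in place of 4-(methoxycarbonyl)pyridin-2-yl on an oxygen on a saturated carbon. Among the compounds with values here, no measured step alters this part of the core; the step from compound 1 to compound 2 sits on the other end and does not bear on it. Within the data shown here, with no step bearing on the change, no direction beyond the scatter is expected, and compound 4 is estimated at 1500 nM, between 400 nM and 6000 nM, which would mean an expected step of a 1.2-fold lower number from compound 3 to compound 4 (0.08 log units; within the scatter).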

Compound 4, half-maximal inhibitory concentration: 745 nM
Compound 4: middle estimate off by 2.0-fold (0.30 log units), on the high side, within the range that was stated.
By their numbers in this assay, from the lowest: compound 4; then compounds 3 and 1 (each within the scatter of the next). At a limit, above all of these: compound 2.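

The ether side of the shared core responds in this assay: the exchange on the oxygen on a saturated carbon gives a 2.4-fold lower number from compound 3 to compound 4 (0.38 log units; beyond the scatter), so the measured change is no longer confined to the amide end. The methoxycarbonyl group is not required for activity at this level, although the exchange removes it and adds the methyl group in one step, so the two contributions cannot be separated. Nothing shown here accounts for the size or direction of this step.

Still open, from the compounds shown here alone, is whether the bare pyridin-2-yl, or an amine or an ethyl group in place of the methyl, would hold this level. Also open, going by these compounds, is whether 6-methylpyridin-2-yl would give a similar step with the amide group of compound 1.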